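The source may report more compounds than this note shows. Statements on the series, on what has been measured and on what is new or still open speak of the compounds shown alone.

In a physicochemical assay for solubility (a lower number here means a less soluble compound, a higher number a more soluble compound), compound 1 `CNC(=O)c1cc(C(=O)N[C@H]2[C@@H]3COC[C@@H]32)cc2c1OC[C@H]2c1ccccc1` gives only a limit, >= 165 ug/mL. Compound 2 `CNC(=O)c1cc(C(=O)N[C@H]2[C@@H]3COC[C@@H]32)cc2c1OC[C@H]2c1ccncc1` also gives only a limit, >= 184 ug/mL. Compound 3 `CNC(=O)c1cc(C(=O)N[C@H]2[C@@H]3COC[C@@H]32)cc2c1OC[C@H]2c1ccccn1` likewise gives a limit, >= 158 ug/mL. Compound 1 therefore has no number, and its rank among the three cannot be read.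

Compound 4 `CNC(=O)c1cc(C(=O)NC)c2c(c1)[C@H](c1ccccc1)CO2` carries methyl on the amide-type nitrogen: one carbon atom in place of a group of 6 heavy atoms (5 carbon, 1 oxygen; one three-membered non-aromatic ring of carbon only, one five-membered non-aromatic ring with 1 hetero atom), on an amide-type nitrogen.

The measured changes lie elsewhere, on a saturated ring carbon. Pyridin-4-yl in place of phenyl is a step that the two limits leave unreadable from compound 1 to compound 2. Pyridin-2-yl in place of phenyl is a step that the two limits leave unreadable from compound 1 to compound 3. Pyridin-2-yl in place of pyridin-4-yl is a step that the two limits leave unreadable from compound 2 to compound 3.

None of these gives a size or direction to carry over, so no change beyond the scatter is expected. The expected step is an at least 1.1-fold lower number from compound 1 to compound 4 (0.04 log units; that floor lies within the scatter). For compound 4 the estimated value is 150 ug/mL, with an expected range of 60 ug/mL to 220 ug/mL.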

Compound 4, solubility: >= 130 ug/mL
Compound 4: only a limit was reported; the forecaster's own chance of this, stated with the estimate: 55%; the middle value is on the limit's open side.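

In this assay compound 4 gives only a limit, >= 130 ug/mL. Compound 1 is a limit too, so the step between compound 1 and compound 4 cannot be read. Going by these compounds, the size and direction of the change from methyl on the amide-type nitrogen remain open.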